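The compounds below may be only part of what the source reports. "The series", "measured", "known", "first", "only" and "open" are said of these compounds alone.

In a physicochemical assay for pharmacokinetics (on this read-out lower numbers stand for a shorter-lived compound and higher numbers for a longer-lived compound), compound 1 (`O=C(NCc1cccc2ccccc12)N1C(=O)c2ccccc2S1(=O)=O`) gives 0.395 h and compound 2 (`CC(NC(=O)N1C(=O)c2ccccc2S1(=O)=O)c1ccccc1`) gives 0.663 h while compound 3 (`COc1ccc(CNC(=O)N2C(=O)c3ccccc3S2(=O)=O)cc1`) gives 0.187 h as the lowest of the three numbers, beyond the scatter from both others. Compound 4 (`O=C(NCc1cccc(Br)c1)N1C(=O)c2ccccc2S1(=O)=O`) carries 3-bromophenyl in place of 4-methoxyphenyl on a saturated chain carbon bound to an amide-type nitrogen. Going by the values given here, no two measured compounds differ in one place only, and no step in this assay is available as a guide. With compound 3 at 0.187 h as the low end of the series, a modest upward move is expected, not clearly beyond the scatter. The expected step is a 1.8-fold higher number from compound 3 to compound 4 (0.25 log units; within the scatter) and this remains an estimate. Compound 4 is estimated at 0.33 h with an expected range from 0.14 h to 0.75 h on this read-out.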

Compound 4, half-life: 0.492 h
Beside the measured number, compound 4's estimate is 1.5-fold (0.17 log units) below it; the range from low to high includes it.
By their numbers in this assay, from the lowest: compound 3; then compounds 1, 4 and 2 (each within the scatter of the next).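

Going by these compounds alone, on a saturated chain carbon bound to an amide-type nitrogen, 3-bromophenyl in place of 4-methoxyphenyl gives a 2.6-fold higher number from compound 3 to compound 4 (0.42 log units; beyond the scatter) in this assay, the first single-place step and one showing that this position can move the half-life. The change alters both the substituent and its place on the ring, so this step does not separate the two.

Still open, as far as these compounds go, is how 3-methoxyphenyl, 4-bromophenyl or an aminophenyl group would read at this position. Nothing available explains the step.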